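This account rests on a few compounds, and the source may have more. Where it says the series, first, only, none or still open, it means among the compounds named here.

Measured in a functional assay on A-375 cells (Homo sapiens) for inhibition, read by CCK-8 assay, with a stated time of 72 h, tested at 2 uM; on this read-out higher numbers stand for more inhibition of growth at the one concentration tested and lower numbers for less inhibition of growth:
- compound 1 `Cc1cc(C)cc(SCc2ccc(/C=C/C(=O)Nc3ccccc3N)cc2)c1`: 8.78%
- compound 2 `Nc1ccccc1NC(=O)c1ccc(CSc2cccc(F)c2)cc1`: 37.7%

Of these two compounds, compound 1 stands lowest at 8.78% and compound 2 stands higher at 37.7% with a gap beyond the usual scatter. Within the data shown here, the two differ in more than one place, so their values give no measured step for any single change.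

The next compound is compound 3 `Nc1ccccc1NC(=O)/C=C/c1ccc(CSc2ccc(C(F)(F)F)cn2)cc1`, which carries 5-(trifluoromethyl)pyridin-2-yl in place of 3,5-dimethylphenyl on a sulfur, with the rest of compound 1 kept: 5-(trifluoromethyl)pyridin-2-yl in place of 3,5-dimethylphenyl on a sulfur. Among the measured compounds shown here, no measured pair shows what this exchange does, so the expectation is loose. Compound 1 at 8.78% leaves little room to fall, and compound 2 at 37.7% shows that a higher number is within reach for a compound with a related structure. A modest upward move is therefore expected, only slightly beyond the scatter, and the estimated step is a number 12.2 percentage points higher from compound 1 to compound 3 (beyond the scatter) on this reading. Compound 3 is estimated at 21% with 5% to 46% as the expected range.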

Compound 3, percent growth inhibition at one concentration: 10.3%
The estimate for compound 3 lay 10.7 percentage points above the measured number; low and high end bracket the measured number.
By their numbers in this assay, from the lowest: compounds 1 and 3 (each within the scatter of the next); then compound 2.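

In this assay, among these compounds, the exchange of 3,5-dimethylphenyl for 5-(trifluoromethyl)pyridin-2-yl, on a sulfur whose other neighbour is a saturated chain carbon, gives the first measured step at this position: a number 1.5 percentage points higher from compound 1 to compound 3 (within the scatter). The two compounds therefore cannot be told apart on this read-out, even though the entering group has more heavy atoms, a hetero atom in its aromatic ring and a hydrogen-bond acceptor that the leaving group lacks. This holds for this one pair only, and nothing measured here accounts for the result.

Compound 2, at 37.7%, differs from both compound 1 and compound 3 in more than one place, so the compounds shown do not tie its value to any single structural change. Also open, on these data alone, is what other groups on the same sulfur would do, such as an unsubstituted phenyl ring, a pyridine ring carrying an amine or a carboxylic acid, or a longer chain, and whether the match between compound 1 and compound 3 would hold with a different remainder of the molecule.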